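The compounds below may be only part of what the source reports. "The series", "measured", "known", "first", "only" and "open" are said of these compounds alone.

Compound 1 `O=C1C[C@H](OCc2cn(C(=O)c3ccccc3)nn2)[C@H]2CO[C@@H]1O2` carries a benzoyl group on an aromatic nitrogen of a five-membered aromatic ring with 3 nitrogen. In a functional assay on MDA-MB-231 cells (Homo sapiens) for cytotoxicity, read by MTT assay, with a stated time of 48 h (on this read-out lower numbers stand for stronger inhibition and higher numbers for weaker inhibition), compound 1 gives 25900 nM. Compound 2 `O=C1C[C@H](OCc2cn(Cc3ccc([N+](=O)[O-])cc3)nn2)[C@H]2CO[C@@H]1O2` gives 25400 nM in this assay, and compound 3 `O=C1C[C@H](OCc2cn(Cc3ccc4ccccc4c3)nn2)[C@H]2CO[C@@H]1O2` gives 23700 nM. Compound 1 has the highest of the three numbers, yet its distance to compound 2 and to compound 3 lies within the usual scatter, so the three values cannot be told apart and no order among them can be read.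

Compound 4 `O=C1C[C@H](OCc2cn(C3CCCCC3)nn2)[C@H]2CO[C@@H]1O2` has not yet been measured. It differs from compound 1 as follows: cyclohexyl in place of benzoyl on an aromatic nitrogen. For the measured compounds named here, no step between two measured compounds anchors this change. Since three rather different groups at this place in compounds 1, 2 and 3 gave values within scatter of one another, the expected step of a 1.0-fold lower number from compound 1 to compound 4 (0.02 log units; within the scatter) is none beyond the scatter. For compound 4 in this assay a value of 25000 nM is estimated, with a range from 10000 nM to 60000 nM.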

Compound 4, half-maximal inhibitory concentration: 24300 nM
Beside the measured number, compound 4's estimate is 1.0-fold (0.01 log units) above it; the range from low to high includes it.
By their numbers in this assay, from the lowest: compounds 3, 4, 2 and 1 (each within the scatter of the next).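

Putting cyclohexyl in place of benzoyl on an aromatic nitrogen gives a 1.1-fold lower number from compound 1 to compound 4 (0.03 log units; within the scatter) in this assay. This step takes away the six-membered aromatic ring, the double bond outside aromatic rings and the hydrogen-bond acceptor of benzoyl all at once, and the number still cannot be told from that of compound 1. Nothing measured here offers a reason for this flat result.

As far as these compounds go, whether a different kind of group on this aromatic nitrogen, such as a carboxylic acid, a primary amine or a small methyl, would give a number beyond the scatter stays open. The shared core is the same in all four compounds, so what a change there would do is open as well.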